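A change at the amide end: from compound 3 to compound 4

The compounds below may be only part of what the source reports. "The series", "measured", "known", "first", "only" and "open" are said of these compounds alone.

Compound 1 `CCC(CC)S(=O)(=O)c1ccc(S(=O)(=O)N2CCC[C@@H](C(=O)N3CCC(F)(F)CC3)C2)cc1` gives 40 nM in a functional assay on BXPC-3 cells (Homo sapiens) for inhibition, read by MTT assay, with a stated time of 7 days; on this read-out higher numbers stand for weaker inhibition and lower numbers for stronger inhibition.
Compound 2 `O=C([C@@H]1CCCN(S(=O)(=O)c2ccc(S(=O)(=O)C3CCC3)cc2)C1)N1CCC(F)(F)CC1` gives 78 nM in this assay.
Compound 3 `CCN(CC)S(=O)(=O)c1ccc(S(=O)(=O)N2CCC[C@@H](C(=O)N3CCC(OC)CC3)C2)cc1` gives 1420 nM in this assay.

Of these three measured compounds, compound 3 carries the highest number, and its distance from both compound 2 and compound 1 is beyond the usual scatter, so it is the weakest inhibitor of the three. Compound 4 `CCN(CC)S(=O)(=O)c1ccc(S(=O)(=O)N2CCC[C@@H](C(=O)NC3CCOCC3)C2)cc1` differs from compound 3 in one place: (oxan-4-yl)amino in place of 4-methoxypiperidin-1-yl on a carbonyl carbon. Going by the values given here, the only measured step between neighbours, a 2.0-fold higher number from compound 1 to compound 2 (0.29 log units; within the scatter), concerns a group on a sulfonyl sulfur at the other end of the shared core and lies within the scatter; it says nothing about exchanging the amide partner. Among the compounds with values here, no measured pair addresses the present change, so the direction of the step is open. In the absence of guidance, the expectation for compound 4 is a number close to that of compound 3, with a wide range to either side. Compound 4 is therefore estimated at 1500 nM, expected to lie between 400 nM and 6000 nM. The expected step is a 1.1-fold higher number from compound 3 to compound 4 (0.02 log units; within the scatter).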

Compound 4, half-maximal inhibitory concentration: 8570 nM
Beside the measured number, compound 4's estimate is 5.7-fold (0.76 log units) below it; the whole stated range lies below it.
By their numbers in this assay, from the lowest: compounds 1 and 2 (each within the scatter of the next); then compound 3; then compound 4.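

The amide end matters in this assay: putting (oxan-4-yl)amino in place of 4-methoxypiperidin-1-yl on the carbonyl carbon gives a 6.0-fold higher number from compound 3 to compound 4 (0.78 log units; beyond the scatter), which means weaker inhibition. The earlier step, a 2.0-fold higher number from compound 1 to compound 2 (0.29 log units; within the scatter), concerned a group on a sulfonyl sulfur, so it said nothing about this position. The entering group has 1 hydrogen-bond donor, the amide hydrogen, where the leaving group has 0 hydrogen-bond donors, but the two groups also differ in how their rings are built, so this one step cannot show which difference counts.

No supporting information bears on what lies behind the step. As far as these compounds go, it remains open how (methyl)(oxan-4-yl)amino, which keeps the oxane ring but lacks the amide hydrogen, or morpholin-4-yl would read on this carbonyl carbon.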